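The compounds below may be only part of what the source reports. "The series", "measured", "known", "first", "only" and "open" are said of these compounds alone.

In a functional assay on KB cells (Homo sapiens) for cytotoxicity, read by spectrophotometry and crystal violet staining (a lower number here means a stronger inhibitor, a higher number a weaker inhibitor), compound 2 `COC(=O)N/N=C/c1c(Cl)n(C2O[C@H](CO)[C@@H](O)[C@H]2O)c2cc(Cl)c(Cl)cc12` gives 20000 nM and compound 1 `N/C(=N\O)c1c(Br)n(C2O[C@H](CO)[C@@H](O)[C@H]2O)c2cc(Cl)c(Cl)cc12` gives 35000 nM, two numbers that lie within the usual scatter of each other. Compound 3 `OC[C@H]1O[C@@H](n2c(Br)nc3cc(Cl)c(Cl)cc32)[C@H](O)[C@@H]1O` is reported as > 100000 nM, which is a limit of the assay and not a number. Within the data shown here, compound 2 therefore sits level with compound 1 on the numbers available, and the only other reading is that limit.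

Compound 4 `OC[C@H]1OC(n2c(Cl)c(/C=N/O)c3cc(Cl)c(Cl)cc32)[C@H](O)[C@@H]1O` has not yet been measured. It differs from compound 2 in one place, with hydroxy in place of (methoxycarbonyl)amino on a double-bonded nitrogen.

Among the measured compounds shown here, no measured pair isolates this change, so the expectation is only a rough one. Compound 1 also carries a hydroxy on a double-bonded nitrogen and gives 35000 nM, so a number of similar size seems likely. The expected step is small and slightly upward, probably not beyond the scatter: a 1.3-fold higher number from compound 2 to compound 4 (0.10 log units; within the scatter). For compound 4 the estimated value is 25000 nM, with an expected range from 8000 nM to 70000 nM.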

Compound 4, half-maximal inhibitory concentration: 25000 nM
Beside the measured number, compound 4's estimate shows no gap at the digits printed; the range from low to high includes it.
By their numbers in this assay, from the lowest: compounds 2, 4 and 1 (each within the scatter of the next). At a limit, above all of these: compound 3.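

Among these compounds, this is the first measured pair that isolates a change at this place, on a double-bonded nitrogen whose other neighbour is a carbon with a double bond to nitrogen. In this assay, hydroxy in place of (methoxycarbonyl)amino gives a 1.3-fold higher number from compound 2 to compound 4 (0.10 log units; within the scatter), so the (methoxycarbonyl)amino group is not required for the cytotoxicity read here, and hydroxy serves equally well within the scatter. No measurement shown bears on the cause of this result.

Compound 1 and compound 3 each differ from these two in more than one place, so no further steps can be read. Going by these compounds, it stays open whether a methoxy group or a longer chain on the same nitrogen would also leave the number within the scatter.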